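A few compounds are considered here, and "the series" means these few. Any claim that something is new, unique, unknown or untested is made for them only; others in the source may bear on it.

Working notes on the series. In a physicochemical assay for solubility, at pH 7 (on this read-out lower numbers stand for lower solubility and higher numbers for higher solubility), compound 1 `O=C(Nc1ncc(Cc2cccc3ccccc23)s1)C1CCCCC1` gives 4 ug/mL, and compound 2 `O=C(CCC1CCCCC1)Nc1ncc(Cc2ccccn2)s1` gives 40 ug/mL. Compound 2 therefore holds the higher of the two numbers, and the gap to compound 1 lies beyond the scatter. The next compound to be read in this assay is compound 3 `O=C(CCC1CCCCC1)Nc1ncc(Cc2ccncc2)s1`, which has the same atoms as compound 2, joined differently: pyridin-4-yl in place of pyridin-2-yl on a saturated chain carbon bound to an aromatic carbon. For the measured compounds named here, no measured pair shows this change, so the expectation rests on the value of compound 2 at 40 ug/mL and on the structural change alone. The expected change, a 1.3-fold higher number from compound 2 to compound 3 (0.10 log units; within the scatter), is none beyond the scatter. For compound 3 the estimated value is 50 ug/mL, with an expected range of 15 ug/mL to 150 ug/mL.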

Compound 3, solubility: 40 ug/mL
For compound 3 the middle estimate is 1.3-fold (0.10 log units) above the measured one, within the range that was stated.
By their numbers in this assay, from the lowest: compound 1; then compounds 2 and 3 (each within the scatter of the next).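

In this assay, pyridin-4-yl in place of pyridin-2-yl on a saturated chain carbon bound to an aromatic carbon gives no change at the digits printed from compound 2 to compound 3 (within the scatter). For the compounds shown here, this is the first step that differs in one place, and it shows that at this position the two pyridine attachments cannot be told apart on this read-out, at least with the rest of compound 2 held constant. No measurement bearing on why the two read alike is at hand.

Still open, from the compounds shown here alone, is whether pyridin-3-yl, or a plain phenyl ring without a ring nitrogen, would read alike at the same place. Also open, going by these compounds, is whether this change would read the same in a compound carrying an amine or a carboxylic acid elsewhere on the shared core.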